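The source may hold more compounds than are shown below. What is called first, only, known or untested is meant among the compounds shown, and "the series" means these compounds.

Among the compounds with values here, compound 2 `O=C(O)c1ccccc1-c1ccc(CCc2ncc(CC3CCCC3)[nH]2)cc1` gives 7.9 nM in an in vitro functional assay on cells for agonist activity at Bombesin receptor subtype-3 (Mus musculus), read by luminescence and calcium flux (a lower number here means that less compound is needed, a higher number that more compound is needed for the effect), the lowest of the three numbers measured so far; compound 1 `CCCCc1cnc(C(C)Cc2ccc(-c3ccccc3C(=O)O)cc2)[nH]1` gives 184 nM and compound 3 `CCCCc1cnc(C(Cc2ccc(-c3ccccc3C(=O)O)cc2)C(C)C)[nH]1` gives 2240 nM. Within the data shown here, the only single-point step between measured compounds is a 12-fold higher number from compound 1 to compound 3 (1.09 log units; beyond the scatter), which sits on a different saturated chain carbon and bears on the present change only as a sign that enlargement near the shared core can cost a good deal. Compound 4 `N#Cc1cccc(Cc2cnc(CCc3ccc(-c4ccccc4C(=O)O)cc3)[nH]2)c1` differs from compound 2 by 3-cyanophenyl in place of cyclopentyl on a saturated chain carbon bound to an aromatic carbon. Among the measured compounds shown here, no measured pair tests an aromatic group at that place, so the size is open; a moderately higher number is expected because a 12-fold higher number from compound 1 to compound 3 (1.09 log units; beyond the scatter) shows a large rise on enlargement elsewhere. Compound 4 is therefore expected at 30 nM, between 6 nM and 150 nM, an expected step of a 3.8-fold higher number from compound 2 to compound 4 (0.58 log units; beyond the scatter).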

Compound 4, half-maximal effective concentration: 20 nM
For compound 4 the middle estimate is 1.5-fold (0.18 log units) above the measured one; low and high end bracket the measured number.
By their numbers in this assay, from the lowest: compound 2; then compound 4; then compound 1; then compound 3.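

In this assay, an aromatic ring is tolerated on the saturated chain carbon bound to an aromatic carbon: 3-cyanophenyl in place of cyclopentyl gives a 2.5-fold higher number from compound 2 to compound 4 (0.40 log units; beyond the scatter) as a modest cost. This enlargement costs far less than the change at a different place, a 12-fold higher number from compound 1 to compound 3 (1.09 log units; beyond the scatter), so size alone at one position does not predict the step at another. Nothing measured accounts for the step.

The compounds shown leave open what the nitrile contributes apart from the ring, which unsubstituted phenyl would separate. Going by these compounds, whether cyclohexyl or a basic piperidinyl group would fit at this position also remains open.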